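Acetyl to bromo on the pendant phenyl of the shared core

The source may hold more compounds than are shown below. What is called first, only, known or untested is meant among the compounds shown, and "the series" means these compounds.

In a functional assay on PC-3 cells (Homo sapiens) for inhibition, read by sulforhodamine B assay, with a stated time of 48 h, tested at 10 uM (a lower number here means less inhibition, a higher number more inhibition at the concentration tested (going by the name of the read-out)), compound 1 `c1ccc(-c2cn3ccnc3c(-c3ccc4ncn(C5CCCCC5)c4c3)n2)cc1` gives 92%, while compound 2 `CC(=O)c1ccc(-c2cn3ccnc3c(-c3ccc4ncn(C5CCCCC5)c4c3)n2)cc1` gives 17.9%. Among the compounds with values here, the only measured step runs a number 74.1 percentage points lower from compound 1 to compound 2 (beyond the scatter), so compound 2 stands lowest of the two numbers, with compound 1 the nearest neighbour and far above it. Compound 3 `Brc1ccc(-c2cn3ccnc3c(-c3ccc4ncn(C5CCCCC5)c4c3)n2)cc1` is the next member; it differs from compound 2 by bromo in place of acetyl on an aromatic carbon on an aromatic carbon of a six-membered aromatic ring of carbon only, para to a large group. Within the data shown here, the one step that bears on this change is a number 74.1 percentage points lower from compound 1 to compound 2 (beyond the scatter), which shows that a group in this place can move the read-out a long way. Bromo is nearer in size to hydrogen than to acetyl, so a partial return toward compound 1 is expected, as the step of a number 42.1 percentage points higher from compound 2 to compound 3 (beyond the scatter). For compound 3 the estimate in this assay is 60%, within 20% to 95%.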

Compound 3, a percentage reported as inhibition, at one concentration (the size of the read-out at that concentration, not a potency): 42.4%
Beside the measured number, compound 3's estimate is 17.6 percentage points above it; measured number inside the range.
By their numbers in this assay, from the lowest: compound 2; then compound 3; then compound 1.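

In this assay, the change from 4-acetylphenyl to 4-bromophenyl reads as a number 24.5 percentage points higher from compound 2 to compound 3 (beyond the scatter) and so regains only part of what acetyl loses. Bromo in place of hydrogen still gives a number 49.6 percentage points lower from compound 1 to compound 3 (beyond the scatter) and shows that a single heavy atom, without a hydrogen-bond acceptor, is enough for a large fall at this place. Both groups shown here stand below hydrogen, but with only these two, the effects of group size and of the acceptor cannot be told apart.

Going by these compounds, whether fluoro, an amine or a carboxylic acid at this place would come closer to compound 1 remains open. These single-concentration readings also give no potency, and nothing available explains the differences between these compounds.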